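Working notes: a demethylation step in a small series

The compounds below may be only part of what the source reports. "The series", "measured", "known", "first", "only" and "open" are said of these compounds alone.

Measured so far:
compound 1, `COc1cc(/C=C2\NC(=S)NC2=O)ccc1O`: 187000 nM
compound 2, `COc1cc(/C=C2\N=C(SC)N(C)C2=O)ccc1O`: 87000 nM

In an assay on isolated protein for inhibition of cystathionine beta-synthase (Homo sapiens), read by fluorescence, in the presence of a further agent that is not named here (on this read-out higher numbers stand for weaker inhibition and lower numbers for stronger inhibition), compound 1 gives 187000 nM, the higher of the two numbers; compound 2 gives 87000 nM, and the gap between the two lies beyond the scatter. Compound 3, `O=C1NC(=S)N/C1=C\c1ccc(O)c(O)c1`, differs from compound 1 by hydrogen in place of methyl on an oxygen on an aromatic ring. Within the data shown here, no measured pair shows this change on its own, so its effect in this assay is unknown; the step of a 1.2-fold lower number from compound 1 to compound 3 (0.10 log units; within the scatter) is expected to be small, with no direction beyond the scatter. Compound 3 is therefore estimated at 150000 nM, within 50000 nM to 450000 nM.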

Compound 3, half-maximal inhibitory concentration: 125000 nM
Compound 3: middle estimate off by 1.2-fold (0.08 log units), on the high side; measured number inside the range.
By their numbers in this assay, from the lowest: compounds 2, 3 and 1 (each within the scatter of the next, the first and the last beyond it).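

The change from methoxy to hydroxy now has a measured pair in this assay, with a 1.5-fold lower number from compound 1 to compound 3 (0.17 log units; within the scatter). On the core of compound 1, hydrogen in place of methyl on an oxygen on an aromatic ring therefore leaves the number within the scatter, so this methyl is not required to hold it at this level. Nothing at hand bears on the reason for this result.

As far as these compounds go, whether an ethyl ether, a longer chain or an amine at this position would move the number beyond the scatter stays open. So does the outcome of the same change on the core of compound 2.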